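The compounds below may be only part of what the source reports. "The series", "measured", "known", "first", "only" and "open" are said of these compounds alone.

Compound 1 `Cc1ccc(S(=O)(=O)Nc2cc(SCCC(=O)N[C@@H](CC(C)C)B(O)O)c(O)c3ccccc23)cc1` and compound 2 `CC(C)C[C@H](NC(=O)CCSc1cc(NS(=O)(=O)c2cccs2)c2ccccc2c1O)B(O)O` share one core, while compound 3 `Cc1ccc(S(=O)(=O)Nc2cc(SC(C)C(=O)N[C@@H](CC(C)C)B(O)O)c(O)c3ccccc23)cc1` and compound 4 `CC(C)C[C@H](NC(=O)C(C)Sc1cc(NS(=O)(=O)c2cccs2)c2ccccc2c1O)B(O)O` share another; the difference between the two cores is not broken down here. In a functional assay on MDA-MB-231 cells (Homo sapiens) for antiproliferative activity, read by sulforhodamine B assay, with a stated time of 72 h (on this read-out lower numbers stand for stronger inhibition and higher numbers for weaker inhibition), compound 1 gives 6150 nM and compound 2 gives 4450 nM. Compound 3 gives 8130 nM in this assay, which is close to the value of compound 1.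

The change from compound 1 to compound 2 is thiophen-2-yl in place of 4-methylphenyl on a sulfonyl sulfur, and it made a step of a 1.4-fold lower number from compound 1 to compound 2 (0.14 log units; within the scatter). The change from compound 3 to compound 4 is thiophen-2-yl in place of 4-methylphenyl on a sulfonyl sulfur, the same change at the same place, only on the other core.

For the measured compounds named here, since the one earlier step was a 1.4-fold lower number from compound 1 to compound 2 (0.14 log units; within the scatter), a step of about the same size is expected from compound 3 to compound 4, namely a 1.4-fold lower number from compound 3 to compound 4 (0.15 log units; within the scatter) in this assay, resting on the single example of compound 1 to compound 2 because a 1.4-fold lower number from compound 1 to compound 2 (0.14 log units; within the scatter) lies within the scatter. For compound 4 the expected value in this assay is therefore 5800 nM, with a likely range from 3000 nM to 11000 nM.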

Compound 4, half-maximal inhibitory concentration: 7450 nM
Beside the measured number, compound 4's estimate is 1.3-fold (0.11 log units) below it, within the range that was stated.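

Replacing 4-methylphenyl with thiophen-2-yl on the sulfonyl sulfur gives, in this assay, a step of a 1.1-fold lower number from compound 3 to compound 4 (0.04 log units; within the scatter). Set beside the earlier example, the change behaves alike on the two cores: the same change on two cores in this assay, a 1.4-fold lower number (0.14 log units; within the scatter) from compound 1 to compound 2 and a 1.1-fold lower number (0.04 log units; within the scatter) from compound 3 to compound 4, 1.3-fold (0.10 log units) apart, within the scatter of two such steps

This shows that the swap leaves the antiproliferative read-out essentially unmoved on both cores, but it does not show that thiophen-2-yl is truly better than 4-methylphenyl, and two small steps cannot establish that the change would carry over the same way to a further core.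

As far as these compounds go, it remains open whether a different group on the sulfonyl sulfur, such as a plain methyl group or a pyridine ring, would move the number beyond the usual scatter. From the compounds shown here alone, it also remains open how this same swap would behave on a third core, for instance one with a longer chain leading to the amide carbonyl.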